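The source may hold more compounds than are shown below. What is called first, only, known or untested is meant among the compounds shown, and "the series" means these compounds.

Working notes on the series. Among the measured compounds shown here, the shared core is the one of compound 1 `COc1ccc(C(=O)Nc2cccc(NC(=O)COc3ccc4c(=O)ccoc4c3)c2)cc1`. For the measured compounds named here, in an assay on isolated protein for inhibition of Rho-associated protein kinase 2 (Homo sapiens), read by scintillation counting, radiometric assay and 33P incorporation, with a stated time of 40 min, in the presence of a further agent that is not named here (on this read-out lower numbers stand for stronger inhibition and higher numbers for weaker inhibition), compound 1 gives 7 nM, the lowest of the three numbers so far. Compound 2 `O=C(COc1ccc2c(=O)ccoc2c1)Nc1cccc(NC(=O)c2ccc(OC(F)(F)F)cc2)c1` gives 77 nM and compound 3 `Cc1cc(C(=O)Nc2cccc(NC(=O)COc3ccc4c(=O)ccoc4c3)c2)ccc1C(F)(F)F` gives 43 nM; the steps of an 11-fold higher number from compound 1 to compound 2 (1.04 log units; beyond the scatter) and a 6.1-fold higher number from compound 1 to compound 3 (0.79 log units; beyond the scatter) show that changes at the end bound to the carbonyl carbon move the number upward. Compound 4 `Cn1ccc(S(=O)(=O)Nc2cccc(NC(=O)COc3ccc4c(=O)ccoc4c3)c2)n1` differs from compound 1 at that same end: a group of 9 heavy atoms (4 carbon, 2 nitrogen, 2 oxygen, 1 sulfur; one five-membered aromatic ring with 2 hetero atoms) in place of a group of 10 heavy atoms (8 carbon, 2 oxygen; one six-membered aromatic ring of carbon only), on a nitrogen on an aromatic ring. Going by the values given here, this change is larger than either measured step, and no measured pair isolates it, so a step upward from compound 1, at least as large as those seen, is expected: a 21-fold higher number from compound 1 to compound 4 (1.33 log units; beyond the scatter). Compound 4 is thus estimated at 150 nM, within 25 nM to 900 nM.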

Compound 4, half-maximal inhibitory concentration: 1350 nM
For compound 4 the middle estimate is 9.0-fold (0.95 log units) below the measured one, outside the stated range (above it).
By their numbers in this assay, from the lowest: compound 1; then compounds 3 and 2 (each within the scatter of the next); then compound 4.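

In this assay, replacing the (4-methoxyphenyl)carbonyl group on the nitrogen with the sulfur-bearing group carrying a five-membered aromatic ring gives a 190-fold higher number from compound 1 to compound 4 (2.29 log units; beyond the scatter). That step exceeds an 11-fold higher number from compound 1 to compound 2 (1.04 log units; beyond the scatter), so this end of the molecule can cost far more than the changes on the aromatic ring of the carbonyl-linked group showed. Nothing available bears on the cause of this step.

On these data alone, both the link to the nitrogen and the ring change together in compound 4, so the share of each remains open. Also open, as far as these compounds go, is how an amine or a carboxylic acid on the aromatic ring of compound 1 would compare with its methoxy group.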